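The source may hold more compounds than are shown below. What is called first, only, known or untested is meant among the compounds shown, and "the series" means these compounds.

Of the compounds shown here, three have so far been measured in an assay on isolated protein for inhibition of serine/threonine-protein kinase D2 (Homo sapiens), read by mobility shift assay, tested at 30 uM; a lower number here means less inhibition, a higher number more inhibition at the concentration tested (going by the name of the read-out). Compound 1, with the structure `CN1CCN(c2ccc(-c3cc4[nH]nc(N)c4c(=O)[nH]3)cc2)CC1`, gives 15% in this assay. Compound 2, with the structure `COc1ccc(-c2c(C)[nH]c(=O)c3c(N)nn(C)c23)cc1`, gives 21% in this assay. Compound 3, with the structure `CC(C)(C)c1cc2nn(-c3ccccc3)c(N)c2c(=O)[nH]1`, gives 15% in this assay. Compound 3 thus stands level with compound 1 at the digits reported, and the number for compound 2 sits within the usual scatter of both, so the three compounds cannot be told apart on these readings; all three show only modest inhibition at the concentration tested.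

Compound 4, with the structure `Nc1c2c(=O)[nH]c(-c3ccccn3)cc2nn1-c1ccccc1`, has not yet been measured in this assay. It differs from compound 3 in one place: pyridin-2-yl in place of tert-butyl on an aromatic carbon. Going by the values given here, no pair of measured compounds differs in a single place, so there is no measured step to lean on. Among the compounds with values here, with only three compounds in hand, all within the scatter of one another, the fair expectation is that the change from compound 3 to compound 4 produces no step beyond the scatter in this assay, in either direction. The expected step is a number 3 percentage points higher from compound 3 to compound 4 (within the scatter). Compound 4 is therefore estimated to give 18% in this assay, with a likely range from 5% to 35%.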

Compound 4, a percentage reported as inhibition, at one concentration (the size of the read-out at that concentration, not a potency): 15%
Beside the measured number, compound 4's estimate is 3 percentage points above it; the measured number falls inside the stated range.
By their numbers in this assay, from the lowest: compounds 1, 3, 4 and 2 (each within the scatter of the next).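

In this assay, going by these compounds alone, putting pyridin-2-yl in place of tert-butyl on the aromatic carbon next to the ring nitrogen gives no change at the digits printed from compound 3 to compound 4 (within the scatter), and this is the first comparison in the set in which only one place differs. The entering group brings a six-membered aromatic ring and a hydrogen-bond acceptor, while the leaving group has neither, yet this swap does not separate the two compounds, so at this position the reading does not distinguish a branched alkyl group from this aromatic ring. Nothing available explains why the reading stays put, and a single swap between two compounds with modest inhibition cannot show whether this position matters more generally.

Still open, as far as these compounds go, is whether a different kind of group on this same carbon, such as a carboxylic acid, a morpholine ring or a longer chain ending in an amine, would move the reading beyond the scatter. From the compounds shown here alone, compound 3 and compound 4 also share the phenyl group on the ring nitrogen, so what happens when that phenyl gives way to a smaller group such as methyl remains unknown for this pair.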